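Indole attachment point and serotonin receptor 7 binding

This account rests on a few compounds, and the source may have more. Where it says the series, first, only, none or still open, it means among the compounds named here.

Measured compounds:
- Compound 1 `O=C1c2ccccc2CCCN1CCN1CCC(Oc2ccccc2)CC1`: 20.4 nM
- Compound 2 `O=C(c1ccc(Cl)cc1)C1CCN(CCN2CCCc3ccccc3C2=O)CC1`: 2.51 nM
- Compound 3 `O=C1c2ccccc2CCCN1CCN1CCC(c2c[nH]c3ccccc23)CC1`: 0.407 nM

In an assay on isolated protein for binding affinity to 5-hydroxytryptamine receptor 7 (Homo sapiens) (on this read-out higher numbers stand for weaker inhibition and lower numbers for stronger inhibition), compound 1 gives the highest of the three numbers. The nearest is compound 2, reached by an 8.1-fold lower number from compound 1 to compound 2 (0.91 log units; beyond the scatter); the furthest is compound 3, reached by a 50-fold lower number from compound 1 to compound 3 (1.70 log units; beyond the scatter). Between the two of them lies a 6.2-fold lower number from compound 2 to compound 3 (0.79 log units; beyond the scatter).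

Compound 4 `O=C1c2ccccc2CCCN1CCN1CCC(n2ccc3ccccc32)CC1` differs from compound 1 by 1H-indol-1-yl in place of phenoxy on a saturated ring carbon. Among the measured compounds shown here, the step that bears most on this is the one from compound 1 to compound 3, where an indole also replaced the phenoxy, though there attached through 1H-indol-3-yl rather than 1H-indol-1-yl; that step was large. The step from compound 1 to compound 2 shows that other replacements of the phenoxy also gave lower numbers. For the measured compounds named here, no measured step compares the two indole attachments directly, so the size is uncertain. A lower number than compound 1 is expected in this assay, with a 6.8-fold lower number from compound 1 to compound 4 (0.83 log units; beyond the scatter) as the expected step. For compound 4 the estimate is 3 nM, within a range from 0.5 nM to 20 nM.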

Compound 4, inhibition constant: 2.75 nM
For compound 4 the middle estimate is 1.1-fold (0.04 log units) above the measured one; low and high end bracket the measured number.
By their numbers in this assay, from the lowest: compound 3; then compounds 2 and 4 (each within the scatter of the next); then compound 1.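

The way the indole is attached to the saturated ring carbon matters in this assay: 1H-indol-1-yl in place of 1H-indol-3-yl gives a 6.8-fold higher number from compound 3 to compound 4 (0.83 log units; beyond the scatter). Even so, indole attached through its ring nitrogen still beats phenoxy, with a 7.4-fold lower number from compound 1 to compound 4 (0.87 log units; beyond the scatter), so the gain over phenoxy is not confined to the 1H-indol-3-yl form. It also cannot be told apart from the (4-chlorophenyl)carbonyl group, with a 1.1-fold higher number from compound 2 to compound 4 (0.04 log units; within the scatter).

No independent measurement here explains why the two indole attachments differ. The compounds shown leave open how a 1H-indol-2-yl group, or a smaller group such as an amine, would compare at this ring carbon.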